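Moving an ester change onto a second core

The compounds below may be only part of what the source reports. "The series", "measured", "known", "first", "only" and "open" are said of these compounds alone.

Measured compounds:
compound 1, `COC(=O)C1C(=O)C=C(Nc2ccc(N3CCN(C)CC3)cc2)CC1c1ccccc1`: 4.02
compound 2, `CCOC(=O)C1C(=O)C=C(Nc2ccc(N3CCN(C)CC3)cc2)CC1c1ccccc1`: 4.39
compound 3, `CCOC(=O)C1C(=O)C=C(Nc2cccc(N3CCN(C)CC3)c2)CC1c1ccccc1`: 4.37

Of the compounds shown here, three have been measured in a physicochemical assay for lipophilicity; a lower number here means a more polar compound, a higher number a more lipophilic compound. Compound 1 has the structure `COC(=O)C1C(=O)C=C(Nc2ccc(N3CCN(C)CC3)cc2)CC1c1ccccc1` and gives 4.02. Compound 2, `CCOC(=O)C1C(=O)C=C(Nc2ccc(N3CCN(C)CC3)cc2)CC1c1ccccc1`, gives 4.39. Compound 3, `CCOC(=O)C1C(=O)C=C(Nc2cccc(N3CCN(C)CC3)c2)CC1c1ccccc1`, gives 4.37. Compound 3 and compound 2 lie within the scatter of each other; compound 1 sits lower than both, beyond the scatter.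

Compound 1 and compound 2 differ in one place, described as hydrogen in place of methyl on a saturated chain carbon bound to an oxygen next to a carbonyl group. That change made the step of a number 0.37 log units lower from compound 2 to compound 1 (beyond the scatter).

Compound 2 and compound 3 are built from the same atoms joined differently; the difference between the two cores is not broken down here.

Compound 4, `COC(=O)C1C(=O)C=C(Nc2cccc(N3CCN(C)CC3)c2)CC1c1ccccc1`, has not yet been measured. Within the data shown here, it differs from compound 3 by hydrogen in place of methyl on a saturated chain carbon bound to an oxygen next to a carbonyl group, which is the same change as the one from compound 2 to compound 1, made at the same kind of place. Since compound 3 in this assay gives 4.37, close to compound 2, a step of about the same size is expected, namely a number 0.37 log units lower from compound 3 to compound 4 (beyond the scatter), because the earlier step was a number 0.37 log units lower from compound 2 to compound 1 (beyond the scatter). Compound 4 is therefore estimated at 4, expected to lie between 3.75 and 4.25.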

Compound 4, partition coefficient: 3.99
Compound 4: middle estimate off by 0.01 log units, on the high side; low and high end bracket the measured number.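

In this assay the change from ethoxycarbonyl to methoxycarbonyl gave a number 0.38 log units lower from compound 3 to compound 4 (beyond the scatter) on one core and a number 0.37 log units lower from compound 2 to compound 1 (beyond the scatter) on the other, so within these four compounds it carried across with the same direction and a very similar size. Among these compounds, this rests on only two matched pairs, each pair sharing one core, so it shows that the step held on these two cores and does not show that it would hold on a third core or for a different read-out. No measurement shown gives a reason for the size of this step, on either core.

The compounds shown leave open how the number would respond to other groups at the same place, such as a longer chain like propoxycarbonyl, or a carboxylic acid or an amide in place of the ester. They also leave open whether the step from ethoxycarbonyl to methoxycarbonyl would keep its size on a core that carries a further group, such as a fluorine or an amine, since both cores here differ from each other only in how the same atoms are joined.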